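The source may report more compounds than this note shows. Statements on the series, on what has been measured and on what is new or still open speak of the compounds shown alone.

Measured in a functional assay on MDA-MB-231 cells (Homo sapiens) for antiproliferative activity, read by MTT assay, with a stated time of 72 h; on this read-out lower numbers stand for stronger inhibition and higher numbers for weaker inhibition:
- compound 1 `CC(C)c1cccc(NC(=O)CCc2cccc3c2B(O)OC3)c1`: 1600 nM
- compound 2 `O=C(CCc1cccc2c1B(O)OC2)Nc1ccc(-c2ccccc2)cc1`: 8800 nM

Of these two, compound 1 holds the lower number and so shows the stronger inhibition, while compound 2 stands higher by more than the usual scatter. The next compound to be tested is compound 3 `COc1ccc(-c2cccc(NC(=O)CCc3cccc4c3B(O)OC4)c2)cc1`, which has the core of compound 1 but carries 4-methoxyphenyl in place of isopropyl on an aromatic carbon, meta to a large group (4-methoxyphenyl in place of isopropyl on an aromatic carbon). Among the compounds with values here, no measured pair isolates such a change, so the expectation rests on thin ground. Compound 2, which also bears an added aromatic ring, gives 8800 nM, and this points to a moderate loss of activity in this assay. The expected change is a 2.5-fold higher number from compound 1 to compound 3 (0.40 log units; beyond the scatter), towards weaker inhibition. The estimate for compound 3 is 4000 nM, with an expected range of 1200 nM to 13000 nM.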

Compound 3, half-maximal inhibitory concentration: 88 nM
Compound 3: the middle estimate sits 45-fold (1.66 log units) above what was measured; measured number outside the range, below it.
By their numbers in this assay, from the lowest: compound 3; then compound 1; then compound 2.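

In this assay, putting 4-methoxyphenyl in place of isopropyl gives an 18-fold lower number from compound 1 to compound 3 (1.26 log units; beyond the scatter), a large step towards stronger inhibition. This shows that the aromatic carbon meta to a large group can carry a much bigger substituent than isopropyl, one that brings a six-membered aromatic ring of carbon only and a hydrogen-bond acceptor, and that the number then falls rather than rises. No data at hand explain this gain.

The compounds shown leave open whether the added ring alone carries this step or the methoxy group shares in it, a question that plain phenyl at this position would address. They also leave open how an amine or a carboxylic acid on that ring, or a longer chain in place of the methoxy group, would read in this assay.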